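Ethyl to butyl at the edge of a dose limit

This account rests on a few compounds, and the source may have more. Where it says the series, first, only, none or still open, it means among the compounds named here.

In a functional assay on the whole organism with Mus musculus as the target (on this read-out higher numbers stand for an effect only at larger amounts of compound and lower numbers for an effect already at smaller amounts), compound 1 (`NC(=O)/C=C/c1cccc(C(F)(F)F)c1`) gives 37.5 mg/kg as its result. In the same test, this assay, compound 2 (`CNC(=O)/C=C(\C)c1cccc(C(F)(F)F)c1`) gives 87.5 mg/kg as its result. Compound 3 (`CCN1C(=O)CCC1(O)c1cccc(C(F)(F)F)c1`) has no exact dose: its entry of > 100 mg/kg is a limit of the assay and not a measured number. Among the results so far, this is the only one of its kind (the limit of > 100 mg/kg in this assay, at which 1 of the 3 values shown sits).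

Compound 4 (`CCCCN1C(=O)CCC1(O)c1cccc(C(F)(F)F)c1`) differs from compound 3 in one place, where an ethyl chain becomes a butyl chain (ethyl in place of hydrogen on a saturated chain carbon, two bonds along the chain from an amide-type nitrogen in a ring).

Among the compounds with values here, no measured pair of compounds shows what this change does. The expectation therefore rests on compound 3 and its limit of > 100 mg/kg as the closest relative, and it stays loose. The expected step of an at least 1.1-fold lower number from compound 3 to compound 4 (0.07 log units; that floor lies within the scatter) is no larger than the usual scatter. For compound 4 the estimate is 85 mg/kg with 40 mg/kg to 170 mg/kg as the expected range, and the assay may again report only a limit.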

Compound 4, dose for half-maximal effect: > 200 mg/kg
Compound 4: a limit, no number (the forecaster's own chance of this, stated with the estimate: 45%); middle value at least 2.3-fold (0.37 log units) away from the limit.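

In this assay compound 3 has only a limit of the assay, > 100 mg/kg. Compound 4 likewise has only a limit, > 200 mg/kg. With two limits and no exact dose, no step can be read between compound 3 and compound 4. The compounds shown leave open whether going from ethyl to butyl changes the dose needed for an effect at all.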